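The compounds below may be only part of what the source reports. "The series", "measured", "known", "first", "only" and "open" are said of these compounds alone.

Series notes. The shared core appears in compound 1 `Clc1ccc([C@@H]2C[C@@H]3Cc4ccc5ccccc5c4N2O3)cc1`, compound 2 `Brc1ccc([C@@H]2C[C@@H]3Cc4ccc5ccccc5c4N2O3)cc1`, compound 3 `Brc1cccc([C@@H]2C[C@@H]3Cc4ccc5ccccc5c4N2O3)c1` and the as yet unmeasured compound 4 `Cc1cccc([C@@H]2C[C@@H]3Cc4ccc5ccccc5c4N2O3)c1`. In an ADME assay on Vero cells (Chlorocebus sabaeus) for cytotoxicity, read by MTT assay, with a stated time of 72 h (on this read-out lower numbers stand for higher toxicity in this test and higher numbers for lower toxicity in this test), compound 1 gives 287000 nM. Compound 2 reaches only the limit of the assay, > 250000 nM, rather than a number. Compound 3 likewise stops at the limit, > 250000 nM. Compound 2 therefore stands at the upper edge of what this assay reports, and two of the three measured values sit there (the limit of > 250000 nM in this assay, at which 2 of the 3 values shown sit). The change under consideration is 3-methylphenyl in place of 4-bromophenyl on a saturated ring carbon. The measured steps that bear on it are a step that the limit leaves unreadable from compound 1 to compound 2, a step that the limit leaves unreadable from compound 1 to compound 3 and a step that the two limits leave unreadable from compound 2 to compound 3; none has a readable size. No measured value moves away from the limit region, so no shift beyond the scatter is expected in this assay. Compound 4 is accordingly estimated at 260000 nM, with a range from 120000 nM to 550000 nM. The implied step, a step that the limit leaves unreadable from compound 2 to compound 4, is an expectation rather than a measurement.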

Compound 4, half-maximal cytotoxic concentration: > 300000 nM
Compound 4 was reported as a limit; the forecaster's own chance of this, stated with the estimate: 55%; middle value at least 1.1-fold (0.06 log units) away from the limit.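

In this assay, the saturated ring carbon next to the ring nitrogen now carries 3-methylphenyl, with no halogen on the aromatic ring, and compound 4 gives > 300000 nM, which is a limit of the assay and not a number. The one readable comparison is an at least 1.0-fold higher number from compound 1 to compound 4 (0.01 log units; that floor lies within the scatter), so no change beyond the scatter is shown, and the steps to compound 4 from compound 2 and from compound 3 cannot be read. Methyl in place of a halogen therefore brings no sign of higher toxicity in this test at this position, and the result adds a further value at a limit: the limit of > 300000 nM in this assay, at which 1 of the 4 values shown sits.

Open, from the compounds shown here alone, is whether an aminomethyl group or a carboxylic acid on the aromatic ring, in place of methyl, would give a number clearly lower than these limits. Also open, going by these compounds, is how far compound 2, compound 3 and compound 4 truly lie beyond their limits, and so whether 4-bromophenyl and 3-methylphenyl differ at all here.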